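The compounds below may be only part of what the source reports. "The series", "measured", "known", "first", "only" and "open" are said of these compounds alone.

In a functional assay on HT-29 cells (Homo sapiens) for inhibition, read by sulforhodamine B assay, with a stated time of 48 h (on this read-out higher numbers stand for weaker inhibition of growth and lower numbers for stronger inhibition of growth), compound 1 (`c1ccc(COc2cccc(NC3=NCCO3)c2)cc1`) gives 800 nM, compound 2 (`O=C(CCl)NC(=O)Nc1cccc(OC2CCCCC2)c1`) gives 3800 nM and compound 3 (`O=C(CCl)NC(=O)Nc1cccc(OC2CCCCCC2)c1`) gives 6900 nM. Compound 3 therefore lies within the scatter of compound 2, while the value of compound 1 is clearly lower. Compound 4 (`O=C(CCl)NC(=O)Nc1cccc(OCc2ccccc2)c1`) differs from compound 3 by benzyl in place of cycloheptyl on an oxygen on an aromatic ring. Among the compounds with values here, the only measured step in this core is a 1.8-fold higher number from compound 2 to compound 3 (0.26 log units; within the scatter), which stays within the scatter. Compound 1 also carries benzyl, but on a different core, so it offers only weak support for a lower number. No step beyond the scatter is expected, and the estimated step is a 1.7-fold lower number from compound 3 to compound 4 (0.24 log units; within the scatter). Compound 4 is expected at 4000 nM, with an estimated range of 1600 nM to 9000 nM.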

Compound 4, concentration for 50% growth inhibition: 6500 nM
Beside the measured number, compound 4's estimate is 1.6-fold (0.21 log units) below it, within the range that was stated.
By their numbers in this assay, from the lowest: compound 1; then compounds 2, 4 and 3 (each within the scatter of the next).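

In this assay, neither a 1.1-fold lower number from compound 3 to compound 4 (0.03 log units; within the scatter) nor a 1.7-fold higher number from compound 2 to compound 4 (0.23 log units; within the scatter) separates benzyl from the cycloheptyl or cyclohexyl groups, so on an oxygen on an aromatic ring, a six-membered aromatic ring of carbon only reads the same as these non-aromatic rings. With benzyl held in both compounds, an 8.1-fold higher number from compound 1 to compound 4 (0.91 log units; beyond the scatter) is beyond the scatter, which places the one clear difference so far in the group on a nitrogen on an aromatic ring. No supporting data bear on either result.

Open, from the compounds shown here alone, is whether an oxygen-linked methyl or a longer chain ending in an amine would also stay within the scatter of these values. Also open, going by these compounds, is how a carboxylic acid on the benzyl ring would read.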